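The source may report more compounds than this note shows. Statements on the series, on what has been measured and on what is new or still open speak of the compounds shown alone.

Measured compounds:
compound 1 `Cc1csc(N)c1C(=O)c1ccc(Cl)cc1` — 1%
compound 2 `CC(C)(C)Cc1c(-c2ccoc2)sc(N)c1C(=O)c1ccc(Cl)cc1` — 1%
compound 3 `CC(C)(C)Cc1c(-c2ccccc2)sc(N)c1C(=O)c1ccc(Cl)c(Cl)c1` — 6%

Of the compounds shown here, three have been measured in an assay on CHO cells for displacement of a labelled ligand from adenosine receptor A3 (Homo sapiens), read by scintillation counting, tested at 10 uM; on this read-out higher numbers stand for more inhibition at the one concentration tested (going by the name of the read-out) and lower numbers for less inhibition. Compound 1 `Cc1csc(N)c1C(=O)c1ccc(Cl)cc1` gives 1%, compound 2 `CC(C)(C)Cc1c(-c2ccoc2)sc(N)c1C(=O)c1ccc(Cl)cc1` gives 1%, and compound 3 `CC(C)(C)Cc1c(-c2ccccc2)sc(N)c1C(=O)c1ccc(Cl)c(Cl)c1` gives 6%. Compound 2 reads the same as compound 1 at the digits printed, and the gap between compound 2 and compound 3 is also within the usual scatter of this assay, so none of the three compounds separates from another. All three sit at the low end of the inhibition scale.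

Compound 4 `CC(C)(C)Cc1c(-c2ccsc2)sc(N)c1C(=O)c1ccc(Cl)cc1` has not yet been measured in this assay. It differs from compound 2 in one place: thiophen-3-yl in place of furan-3-yl on an aromatic carbon. The change replaces one five-membered aromatic ring with a single hetero atom by another of the same kind; no donor or acceptor is added or removed and no charge is introduced.

Going by the values given here, no pair of measured compounds that differ in only one place is available, so the effect of this kind of swap cannot be read from the data. Given that compound 2 gives 1% and that compound 1 and compound 3 lie within the scatter of it, the step from compound 2 to compound 4 in this assay is expected to be a number 2 percentage points higher from compound 2 to compound 4 (within the scatter), that is, no change beyond the scatter. Compound 4 is therefore estimated to give 3% in this assay, with a range from 0% to 12%.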

Compound 4, a percentage reported as inhibition, at one concentration (the size of the read-out at that concentration, not a potency): 4%
Beside the measured number, compound 4's estimate is 1 percentage points below it; the range from low to high includes it.
By their numbers in this assay, from the lowest: compounds 1, 2, 4 and 3 (each within the scatter of the next).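

In this assay, going by these compounds alone, putting thiophen-3-yl in place of furan-3-yl gives a number 3 percentage points higher from compound 2 to compound 4 (within the scatter) and is the first change in this set that can be read in one place. On this aromatic carbon, next to the ring sulfur and next to the ring atom that bears a neopentyl group, exchanging the oxygen of one five-membered aromatic ring for the sulfur of another therefore leaves the read-out within the usual scatter, with the counts of heavy atoms, hydrogen-bond donors and hydrogen-bond acceptors unchanged under HOW the two groups compare. Nothing measured in this set offers an explanation for this result.

The compounds shown leave open whether any other kind of group on this carbon, such as an amine, a carboxylic acid or a longer chain, would separate from compound 2 beyond the scatter. They also leave open whether the swap of furan-3-yl for thiophen-3-yl would read the same if the neopentyl group were replaced by a methyl group or an ethyl chain, or if the group of 9 heavy atoms carried something else.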